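The compounds below may be only part of what the source reports. "The series", "measured", "known", "first", "only" and "open" are said of these compounds alone.

The measured compounds:
compound 1, `O=C(Nc1ccc(Sc2nc3ccccc3s2)c(Cl)c1)c1cc(Br)cc(Br)c1`: > 100000 nM in an ADME assay on HEK293 cells (Homo sapiens) for cytotoxicity, read by reporter gene assay and resazurin assay, with a stated time of 48 h (a higher number here means that more compound is tolerated, a lower number that less compound is tolerated), a limit of the assay rather than a number.
compound 2, `O=C(Nc1cccc(Cl)c1)c1cccc(Br)c1`: 51000 nM in this assay.
compound 3, `O=C(Nc1ccc(Sc2nc3ccccc3s2)c(Cl)c1)c1cc(Br)cc(Br)c1O`: 76000 nM in this assay.

Compound 1 sits at the limit of > 100000 nM in this assay, at which 1 of the 3 values shown sits, so only a limit is known for it. Compound 3 shares the core of compound 1 and differs from it by hydroxy in place of hydrogen on an aromatic carbon; the step is an at least 1.3-fold lower number from compound 1 to compound 3 (0.11 log units; that floor lies within the scatter). Compound 2 has a different core; the difference between the two cores is not broken down here. The numbers of compound 2 and compound 3 lie within the usual scatter of each other.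

Compound 4, `O=C(Nc1cccc(Cl)c1)c1cc(Br)ccc1O`, is not yet measured. It differs from compound 2 by hydroxy in place of hydrogen on an aromatic carbon. This is the same kind of change as from compound 1 to compound 3, though not the same: there the entering hydroxy also stood ortho to a bromo group. Resting on the step of an at least 1.3-fold lower number from compound 1 to compound 3 (0.11 log units; that floor lies within the scatter), the step of a 1.2-fold lower number from compound 2 to compound 4 (0.08 log units; within the scatter) is expected. Compound 4 is therefore expected to give 42000 nM in this assay.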

Compound 4, half-maximal cytotoxic concentration: 15000 nM
Estimate against measurement, compound 4: 2.8-fold (0.45 log units) above; measured number inside the range.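

Hydroxy in place of hydrogen, on the aromatic carbon para to a bromo group, gives a 3.4-fold lower number from compound 2 to compound 4 (0.53 log units; beyond the scatter) in this assay, so on the core of compound 2 this change clearly reduces the amount of compound tolerated. Setting this result beside the earlier step shows the direction can be the same on both cores, but it does not give the size of the change on the core of compound 1, nor does it show that the change carries over unaltered: the same change on two cores in this assay, an at least 1.3-fold lower number (0.11 log units; that floor lies within the scatter) from compound 1 to compound 3 and a 3.4-fold lower number (0.53 log units; beyond the scatter) from compound 2 to compound 4; the limit leaves it open whether they differ. The earlier step starts from compound 1, whose value is a limit of the assay and not a number: the limit of > 100000 nM in this assay, at which 1 of the 4 values shown sits.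

Still open, on these data alone, is whether a methoxy group or an amine on the same aromatic carbon would lower the number as hydroxy does. Also open, as far as these compounds go, is whether hydroxy on another carbon of that ring would give a step of similar size.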